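This account rests on a few compounds, and the source may have more. Where it says the series, first, only, none or still open, it means among the compounds named here.

Measured so far in a functional assay on MDA-MB-231 cells (Homo sapiens) for inhibition, read by MTT assay; on this read-out higher numbers stand for weaker inhibition of growth and lower numbers for stronger inhibition of growth:
compound 1 `CC1=C(/C=C/C(C)=C/C=C/C(C)=C\C(=O)Nc2ccccc2)C(C)(C)CCC1n1ccnc1`: 1740 nM
compound 2 `CC1=C(/C=C/C(C)=C/C=C/C(C)=C\C(=O)Nc2ccc(F)cc2)C(C)(C)CCC1n1ccnc1`: 4950 nM
compound 3 `CC1=C(/C=C/C(C)=C/C=C/C(C)=C\C(=O)NCc2ccc(O)cc2)C(C)(C)CC=C1c1cncnc1`: 11500 nM

Compound 2, at 4950 nM, holds the second highest of the three numbers, with compound 1 lower and compound 3 higher, and both gaps lie beyond the scatter.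

Next in line is compound 4 `CC1=C(/C=C/C(C)=C/C=C/C(C)=C\C(=O)NCc2ccc(F)cc2)C(C)(C)CCC1n1ccnc1`, not yet measured in this assay. It differs from compound 2 by 4-fluorobenzyl in place of 4-fluorophenyl on an amide-type nitrogen.

Direct evidence on this change is lacking. Within the data shown here, the only measured step at a single place, a 2.8-fold higher number from compound 1 to compound 2 (0.45 log units; beyond the scatter), is modest and concerns fluoro in place of hydrogen on an aromatic carbon, so it shows only that this series can move on a small edit. Among the measured compounds shown here, compound 3, at 11500 nM, is the only measured compound with a benzyl-type group on that nitrogen. It also differs from compound 2 elsewhere, so it offers no more than a weak hint towards a higher number.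

A small move in that direction is expected, probably not clearing the scatter: the estimated step is a 1.3-fold higher number from compound 2 to compound 4 (0.12 log units; within the scatter). For compound 4 the estimated value is 6500 nM, with an expected range of 2700 nM to 15000 nM.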

Compound 4, concentration for 50% growth inhibition: 1410 nM
For compound 4 the middle estimate is 4.6-fold (0.66 log units) above the measured one; measured number outside the range, below it.
By their numbers in this assay, from the lowest: compounds 4 and 1 (each within the scatter of the next); then compound 2; then compound 3.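

In this assay, the group on the amide-type nitrogen can move the number in this series on its own: 4-fluorobenzyl in place of 4-fluorophenyl gives a 3.5-fold lower number from compound 2 to compound 4 (0.55 log units; beyond the scatter) and so reverses the direction seen with a 2.8-fold higher number from compound 1 to compound 2 (0.45 log units; beyond the scatter) for the fluoro edit on the phenyl ring. The fluoro group does not go with a higher number in every setting, since 4-fluorobenzyl in place of phenyl gives a 1.2-fold lower number from compound 1 to compound 4 (0.09 log units; within the scatter) and leaves compound 4 within the scatter of compound 1 even though it carries a fluoro group too. Nothing shown accounts for either step or says why the fluoro group counts in compound 2 but not in compound 4.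

With plain benzyl absent from the compounds shown on this core, the contributions of the added methylene and of the fluoro group to the step cannot be separated. Also open, as far as these compounds go, is how far the tolerance at this nitrogen extends, for example to a longer chain such as 2-phenylethyl, or to a benzyl group carrying an amine or a carboxylic acid on its ring.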